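Chloro for Fluoro on the Anilino Ring of Two Series

This account rests on a few compounds, and the source may have more. Where it says the series, first, only, none or still open, it means among the compounds named here.

Measured compounds in a functional assay on NCI-H1975 cells (Homo sapiens) for antiproliferative activity, read by MTT assay, with a stated time of 72 h; on this read-out higher numbers stand for weaker inhibition and lower numbers for stronger inhibition:
compound 1 `COc1cc2ncnc(Nc3cccc(Cl)c3)c2cc1OCCCCC(=O)Nc1ccc(S(N)(=O)=O)cc1`: 33200 nM
compound 2 `COc1cc2ncnc(Nc3cccc(F)c3)c2cc1OCCCCC(=O)Nc1ccc(S(N)(=O)=O)cc1`: > 40000 nM
compound 3 `NS(=O)(=O)c1ccc(NC(=S)Nc2ccc3ncnc(Nc4cccc(F)c4)c3c2)cc1`: 9660 nM

Of the compounds shown here, three have been measured in this assay. Compound 1 gives 33200 nM. For compound 2 the assay reports only a limit, > 40000 nM, and no number. Compound 3 gives 9660 nM, the lowest of the two numbers; its nearest neighbour is compound 1, whose number is higher by a gap beyond the usual scatter. How the core of compound 2 differs from the core of compound 3 is not broken down here.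

Compounds 2 and 1 share a core and differ in one place: chloro in place of fluoro on an aromatic carbon. The step that this change made is an at least 1.2-fold lower number from compound 2 to compound 1 (0.08 log units; that floor lies within the scatter); since one of the two values is a limit (the limit of > 40000 nM in this assay, at which 1 of the 3 values shown sits), only a floor for the step is known.

Compound 4 `NS(=O)(=O)c1ccc(NC(=S)Nc2ccc3ncnc(Nc4cccc(Cl)c4)c3c2)cc1` is not yet measured. It differs from compound 3 by chloro in place of fluoro on an aromatic carbon, the same change as from compound 2 to compound 1, in the same place.

Resting on that earlier step, which sets only a floor within the scatter, a modest lowering is expected: a 1.8-fold lower number from compound 3 to compound 4 (0.24 log units; within the scatter). Compound 4 is therefore estimated at 5500 nM, with the expectation that a repeat would fall between 1800 nM and 16000 nM.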

Compound 4, half-maximal inhibitory concentration: 39800 nM
The estimate for compound 4 lay 7.2-fold (0.86 log units) below the measured number; measured number outside the range, above it.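

In this assay, putting chloro in place of fluoro on an aromatic carbon gave a 4.1-fold higher number from compound 3 to compound 4 (0.61 log units; beyond the scatter), so on this core the change raised the number by more than the usual scatter. The change therefore did not carry over from one core to the other, and the earlier step proved a poor guide to this one, even though the group that left, the group that entered and their place on the 3-substituted phenyl ring were the same in both pairs: the same change on two cores in this assay, an at least 1.2-fold lower number (0.08 log units; that floor lies within the scatter) from compound 2 to compound 1 and a 4.1-fold higher number (0.61 log units; beyond the scatter) from compound 3 to compound 4, at least 4.9-fold (0.69 log units) apart, beyond the scatter of two such steps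

Compound 2 stands at a limit of the assay and not at a number, so the earlier step is known only as a floor, and how far it really lies from the new step stays unknown: the limit of > 40000 nM in this assay, at which 1 of the 4 values shown sits.

The compounds shown do not reveal which part of the two cores separates the two steps, and with only two matched pairs no rule can be drawn for this change across the series. Also open, going by these compounds, is whether bromo or methyl in the same place would move the number on each core as chloro did, or whether a third core carrying the same fluoro and chloro pair would side with either of these two.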